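Fluoro in place of hydrogen on compound 2

The source may hold more compounds than are shown below. What is called first, only, known or untested is meant among the compounds shown, and "the series" means these compounds.

Measured so far in a functional assay on V79 cells (Cricetulus griseus) for cytotoxicity, read by colony formation; a higher number here means a weaker inhibitor, a lower number a stronger inhibitor:
Compound 1 `Nc1c(F)c(N2CCC(N)C2)cc2c1c(=O)c(C(=O)O)cn2C1CC1` gives 54 ug/mL
Compound 2 `Cc1c(F)c(N2CCC(N)C2)cc2c1c(=O)c(C(=O)O)cn2C1CC1` gives 14 ug/mL
Compound 3 `NC1CCN(c2cc3c(c(O)c2F)c(=O)c(C(=O)O)cn3C2CC2)C1` gives 72 ug/mL

Compound 2 has the lowest number of the three. Compound 4 `Cc1c(F)c(N2CCC(N)C2)c(F)c2c1c(=O)c(C(=O)O)cn2C1CC1` carries fluoro in place of hydrogen on an aromatic carbon, ortho to the 3-aminopyrrolidin-1-yl group. Among the measured compounds shown here, no measured step touches that carbon. All three swap the group para to it: a 3.9-fold lower number from compound 1 to compound 2 (0.59 log units; beyond the scatter), a 5.1-fold higher number from compound 2 to compound 3 (0.71 log units; beyond the scatter) and a 1.3-fold higher number from compound 1 to compound 3 (0.12 log units; within the scatter). They show that one small swap can move the number in this assay, but they give no direction for this change. Only a small drop is therefore expected, a 1.6-fold lower number from compound 2 to compound 4 (0.19 log units; within the scatter). For compound 4 the estimate is 9 ug/mL, with an expected range of 3 ug/mL to 30 ug/mL.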

Compound 4, half-maximal inhibitory concentration: 11 ug/mL
Estimate against measurement, compound 4: 1.2-fold (0.09 log units) below; low and high end bracket the measured number.
By their numbers in this assay, from the lowest: compounds 4 and 2 (each within the scatter of the next); then compounds 1 and 3 (each within the scatter of the next).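

In this assay, fluoro in place of hydrogen on the aromatic carbon ortho to the 3-aminopyrrolidin-1-yl group gives a 1.3-fold lower number from compound 2 to compound 4 (0.10 log units; within the scatter), a step within the scatter. Among the compounds shown here, this is the first reading at this carbon, and with the methyl group para to it, a fluoro here does not shift the number beyond the scatter. No measurement at hand offers an explanation for this result.

Going by these compounds, whether a chloro, methoxy or amino group on this carbon would behave the same stays open. So does whether fluoro here would do the same with amino or hydroxy in place of the methyl group.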